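Permeability notes on the furan-2-yl replacement in compound 4

A few compounds are considered here, and "the series" means these few. Any claim that something is new, unique, unknown or untested is made for them only; others in the source may bear on it.

Compound 1 `COc1ccc(Cn2c(-c3ccccc3)c(-c3ccccc3)c3c(=N)n([C@H]4CC[C@H](O)CC4)cnc32)cc1` in an ADME assay for permeability, using PAMPA, with a stated time of 30 min, at pH 7.4; a higher number here means that the compound crosses the layer faster, a lower number that the compound crosses the layer more slowly: > 1000 10^-6 cm/s, a limit of the assay.
Compound 3 `COc1ccc(Cn2c(-c3ccccc3)c(-c3ccccc3)c3c(=N)n(CCCO)cnc32)cc1` in this assay: > 1000 10^-6 cm/s, also a limit.
Compound 2 `N=c1c2c(-c3ccccc3)cn(Cc3ccccc3)c2ncn1CCO` in this assay: 1270 10^-6 cm/s.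

Among the measured compounds shown here, compound 2 is the only compound of the three with a number in this assay; the other two values are limits, as the limit of > 1000 10^-6 cm/s in this assay, at which 2 of the 3 values shown sit, shows. For the measured compounds named here, the one measured step, a step that the two limits leave unreadable from compound 1 to compound 3, cannot be read. Compound 4 `N=c1c2c(-c3ccccc3)cn(Cc3ccccc3)c2ncn1Cc1ccco1` differs from compound 2 by furan-2-yl in place of hydroxymethyl on a saturated chain carbon bound to an aromatic nitrogen. Going by the values given here, no measured step covers this change, so the expectation rests on the uniformly high values of the series. For compound 4 in this assay no drop beyond the scatter is expected. The estimated step is a 1.0-fold higher number from compound 2 to compound 4 (0.01 log units; within the scatter). Compound 4 is expected to give about 1300 10^-6 cm/s, between 600 10^-6 cm/s and 2600 10^-6 cm/s, with a fair chance that only a limit is reported.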

Compound 4, apparent permeability: 1740 10^-6 cm/s
Compound 4: the middle estimate sits 1.3-fold (0.13 log units) below what was measured; measured number inside the range.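

Among the compounds shown here, the change of furan-2-yl in place of hydroxymethyl on a saturated chain carbon bound to an aromatic nitrogen gives the first readable step in this assay, a 1.4-fold higher number from compound 2 to compound 4 (0.14 log units; within the scatter). This place on the shared core therefore takes a five-membered aromatic ring, with the hydrogen-bond donor of hydroxymethyl gone, and the read-out stays within the scatter. That rests on this single pair.

As far as these compounds go, whether an amine or a carboxylic acid at this place would do the same remains open. Compound 1 and compound 3 remain limits, and the step between them cannot be read: the limit of > 1000 10^-6 cm/s in this assay, at which 2 of the 4 values shown sit.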